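From compound 2 to compound 3: the methoxymethoxy group goes

The compounds below may be only part of what the source reports. "The series", "measured", "known", "first", "only" and "open" are said of these compounds alone.

Working values in an ADME assay on HT-29 cells (Homo sapiens) for cytotoxicity, read by MTT assay, with a stated time of 72 h; a lower number here means a stronger inhibitor, a higher number a weaker inhibitor:
- compound 1 `COc1ccc(C2=C(c3cc(OC)c(OC)c(OC)c3)C(=O)CC2O[SiH2]C(C)(C)C)cc1`: > 100 ug/mL, a limit of the assay
- compound 2 `COCOc1cc(C2=C(c3cc(OC)c(OC)c(OC)c3)C(=O)CC2O[SiH2]C(C)(C)C)ccc1OC`: 43 ug/mL
- compound 3 `COc1cc(C2=C(c3cc(C)c(OC)c(C)c3)C(O[SiH2]C(C)(C)C)CC2=O)cc(OC)c1OC`: not yet measured

Going by the values given here, compound 2 carries the only actual number, as the one other value is a limit. Compound 3 differs from it in one place: 4-methoxy-3,5-dimethylphenyl in place of 4-methoxy-3-(methoxymethoxy)phenyl on a double-bonded ring carbon. The change puts 4-methoxy-3,5-dimethylphenyl in place of 4-methoxy-3-(methoxymethoxy)phenyl on a double-bonded ring carbon.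

Among the compounds with values here, one measured step bears on this: an at least 2.3-fold lower number from compound 1 to compound 2 (0.36 log units; beyond the scatter), with methoxymethoxy in place of hydrogen on an aromatic carbon. That step is beyond the scatter, and its size is open on one side because of the limit of > 100 ug/mL in this assay, at which 1 of the 2 values shown sits. Compound 3 gives up the group gained in an at least 2.3-fold lower number from compound 1 to compound 2 (0.36 log units; beyond the scatter), so a modest move to a higher number in this assay is expected. Within the data shown here, no measured step tests the two methyl groups, and a reading that is only a limit remains possible. The expected change is a 1.6-fold higher number from compound 2 to compound 3 (0.21 log units; within the scatter). For compound 3 the estimate is 70 ug/mL, with an expected range from 25 ug/mL to 160 ug/mL.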

Compound 3, half-maximal inhibitory concentration: 10 ug/mL
Compound 3: the middle estimate sits 7.0-fold (0.85 log units) above what was measured, outside the stated range (below it).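

This position on the double-bonded ring carbon tolerates more than the methoxymethoxy-bearing aryl group: in this assay, the exchange of 4-methoxy-3-(methoxymethoxy)phenyl for 4-methoxy-3,5-dimethylphenyl gives a 4.3-fold lower number from compound 2 to compound 3 (0.63 log units; beyond the scatter), so the methoxymethoxy group is not needed for a lower number in this series. Compared with the plain 4-methoxyphenyl group, the 4-methoxy-3,5-dimethylphenyl group gives an at least 10-fold lower number from compound 1 to compound 3 (1.00 log units; beyond the scatter), which means that two different additions to the 4-methoxyphenyl group, methoxymethoxy in compound 2 and the two methyl groups in compound 3, both lower the number. The size of that second step is open on one side, as compound 1 is only a limit of the assay: the limit of > 100 ug/mL in this assay, at which 1 of the 3 values shown sits.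

The compounds shown do not separate the loss of methoxymethoxy from the gain of the two methyl groups in the step to compound 3, nor do they show whether both methyl groups are required. On these data alone, how a free hydroxyl, an amine or a chlorine would read on this aryl ring remains open, as does any replacement of the silyl ether carried by all three compounds.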